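The source may report more compounds than this note shows. Statements on the series, on what has been measured and on what is new or still open speak of the compounds shown alone.

Compound 1 `Cn1c(-c2ccc(NC(=O)CSC3=NCCS3)cc2)nc(-c2ccccc2)c1-c1ccccc1`: 10.3%
Compound 2 `CCN1CCN(CC(=O)Nc2ccc(-c3nc(-c4ccccc4)c(-c4ccccc4)n3C)cc2)CC1`: 4.7%

In a functional assay on MCF7 cells (Homo sapiens) for cytotoxicity, read by MTT assay, with a stated time of 24 h, tested at 0.64 ug/mL (a lower number here means a weaker effect, a higher number a stronger effect of the compound at the concentration tested), compound 2 gives 4.7% and compound 1 gives 10.3%; the step of a number 5.6 percentage points lower from compound 1 to compound 2 (within the scatter) leaves the two within the scatter of each other. Compound 3 `Cc1ccc(CN2CCN(CC(=O)Nc3ccc(-c4nc(-c5ccccc5)c(-c5ccccc5)n4C)cc3)CC2)cc1` differs from compound 2 by 4-methylphenyl in place of methyl on a saturated chain carbon bound to an amine nitrogen in a ring. Going by the values given here, the only measured step, a number 5.6 percentage points lower from compound 1 to compound 2 (within the scatter), alters a group on a saturated chain carbon bound to a carbonyl carbon, a different place, so it offers little guidance on this change. The expected step is therefore a number 3.3 percentage points higher from compound 2 to compound 3 (within the scatter), nothing beyond the scatter. Compound 3 is estimated at 8%, with a range from 0% to 25%.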

Compound 3, a percentage reported as activity, at one concentration (the size of the read-out at that concentration, not a potency): 9.4%
The estimate for compound 3 lay 1.4 percentage points below the measured number, within the range that was stated.
By their numbers in this assay, from the lowest: compounds 2, 3 and 1 (each within the scatter of the next).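

Putting 4-methylphenyl in place of methyl on a saturated chain carbon bound to an amine nitrogen in a ring gives a number 4.7 percentage points higher from compound 2 to compound 3 (within the scatter) in this assay. So at this position, even the exchange of a single carbon for an added aromatic ring does not move the read-out past the usual spread of repeats. No measured evidence explains this result.

Going by these compounds, whether a carboxylic acid or an amine in place of 4-methylphenyl would produce a step beyond the scatter stays open.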